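This account rests on a few compounds, and the source may have more. Where it says the series, first, only, none or still open, it means among the compounds named here.

Series notes. Compound 1 `Cc1cc(C(=O)O)nn1Cc1cc(Br)ccc1OCc1ccccc1`, compound 2 `Cc1cc(C(=O)Nc2ccc(F)cc2)nn1Cc1cc(Cl)ccc1OCc1ccccc1` and compound 3 `Cc1cc(C(N)=O)nn1Cc1cc(Cl)ccc1OCC(C)C` have been measured in a physicochemical assay for lipophilicity, at pH 7.4; a higher number here means a more lipophilic compound, a lower number a more polar compound. Compound 1 gives 1.2, compound 2 gives 3 and compound 3 gives 3.1. Compound 2 thus stands second highest of the three: its gap to compound 3 lies within the scatter, while its gap to compound 1 lies beyond it. Compound 4 `CCOC(=O)Nc1cc(C)n(Cc2cc(Cl)ccc2OCc2ccccc2)n1` has not yet been measured in this assay. Relative to compound 2 it carries (ethoxycarbonyl)amino in place of (4-fluorophenyl)carbamoyl on an aromatic carbon. Going by the values given here, no step between measured compounds that differ in one place is available, so the direction is judged from the change itself: the group that leaves is the larger and holds an aromatic ring, the group that enters holds no ring, and a decrease beyond the scatter is expected, in the order of a number 0.70 log units lower from compound 2 to compound 4 (beyond the scatter). Compound 4 is accordingly estimated at 2.3, with a range from 1.7 to 2.9.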

Compound 4, distribution coefficient: > 3.7
Compound 4 ended at the assay's limit (the forecaster's own chance of this, stated with the estimate: 2%); middle value at least 1.40 log units away from the limit.
By their numbers in this assay, from the lowest: compound 1; then compounds 2 and 3 (each within the scatter of the next). At a limit, above all of these: compound 4.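

In this assay compound 4 gives > 3.7, which is a limit of the assay and not a number. Going by these compounds alone, on this aromatic carbon, (ethoxycarbonyl)amino in place of (4-fluorophenyl)carbamoyl gives a number at least 0.70 log units higher from compound 2 to compound 4 (beyond the scatter), so here the smaller group without a ring gives the higher number, something the earlier compounds could not show. Only the lowest possible size of this step can be read: the limit of > 3.7 in this assay, at which 1 of the 4 values shown sits.

Going by these compounds, how a free amine or a longer chain, such as (butoxycarbonyl)amino, would read on this aromatic carbon remains open. On these data alone, whether the same change gives a step of this direction on the core of compound 3 also remains open.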